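The compounds below may be only part of what the source reports. "The series", "measured", "known", "first", "only" and "open" are said of these compounds alone.

The measured compounds:

Compound 1, `COc1ncc(-c2ccc3c(c2)N(c2ccccc2)C(=O)CO3)cc1NS(=O)(=O)c1ccc(F)cc1`: 8870 nM
Compound 2, `COc1ncc(-c2ccc3c(c2)N(C2CC2)C(=O)CO3)cc1NS(=O)(=O)c1ccc(F)cc1`: 35200 nM
Compound 3, `O=C1COc2ccc(-c3cnc(Cl)c(NS(=O)(=O)c4ccc(F)cc4)c3)cc2N1c1ccccc1`: > 40000 nM

In a functional assay on MCF7 cells (Homo sapiens) for antiproliferative activity, read by MTT assay, with a stated time of 72 h (a lower number here means a stronger inhibitor, a higher number a weaker inhibitor), compound 1 gives 8870 nM. Compound 2 differs from it by cyclopropyl in place of phenyl on an amide-type nitrogen in a ring, and the step is a 4.0-fold higher number from compound 1 to compound 2 (0.60 log units; beyond the scatter). Compound 3 differs from compound 1 by chloro in place of methoxy on an aromatic carbon, giving an at least 4.5-fold higher number from compound 1 to compound 3 (0.65 log units; beyond the scatter). The value of compound 3 is a limit of this assay and not a number, as the limit of > 40000 nM in this assay, at which 1 of the 3 values shown sits, records.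

Compound 4, `O=C1COc2ccc(-c3cnc(Cl)c(NS(=O)(=O)c4ccc(F)cc4)c3)cc2N1C1CC1`, has not yet been measured in this assay. It differs from compound 3 by cyclopropyl in place of phenyl on an amide-type nitrogen in a ring, the same change that separates compound 1 from compound 2, and the place is the same in both pairs. The two cores differ by the change already described between compound 1 and compound 3.

Because the earlier step was a 4.0-fold higher number from compound 1 to compound 2 (0.60 log units; beyond the scatter), the change is expected to move compound 4 in the same direction. Since compound 3 already sits at a limit, compound 4 is estimated to give 160000 nM, between 40000 nM and 600000 nM, most likely reported only as a limit; the step expected is a step that the limit leaves unreadable from compound 3 to compound 4.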

Compound 4, half-maximal inhibitory concentration: 16700 nM
The estimate for compound 4 lay 9.6-fold (0.98 log units) above the measured number, outside the stated range (below it).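

In this assay, cyclopropyl in place of phenyl on the amide-type nitrogen gives an at least 2.3-fold lower number from compound 3 to compound 4 (0.37 log units; beyond the scatter), so the change does not carry over from the core of compound 1 to the chloro core, and its direction reverses: the same change on two cores in this assay, a 4.0-fold higher number (0.60 log units; beyond the scatter) from compound 1 to compound 2 and an at least 2.3-fold lower number (0.37 log units; beyond the scatter) from compound 3 to compound 4, at least 9.5-fold (0.97 log units) apart, beyond the scatter of two such steps. Read the other way, chloro in place of methoxy on the aromatic carbon gives a 2.1-fold lower number from compound 2 to compound 4 (0.32 log units; beyond the scatter), which also runs against what the same change did on the phenyl compounds: the same change on two cores in this assay, an at least 4.5-fold higher number (0.65 log units; beyond the scatter) from compound 1 to compound 3 and a 2.1-fold lower number (0.32 log units; beyond the scatter) from compound 2 to compound 4, at least 9.5-fold (0.97 log units) apart, beyond the scatter of two such steps. The value of compound 3 is a limit and not a number, so these compounds show that the reversal exists but not its exact size or its cause: the limit of > 40000 nM in this assay, at which 1 of the 4 values shown sits.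

Going by these compounds, whether the reversal also holds for other groups on the amide-type nitrogen, such as a methyl or a longer alkyl chain, stays open. So does whether it holds with a bromo or an amine in place of the methoxy on the aromatic carbon.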